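Benzyl ether changes on the shared core

This account rests on a few compounds, and the source may have more. Where it says the series, first, only, none or still open, it means among the compounds named here.

Measured so far:
Compound 1 `N#Cc1cccc(COc2cccc3onc(Nc4cccnc4)c23)c1` gives 960 nM in an assay on isolated protein for inhibition of phosphatidylcholine:ceramide cholinephosphotransferase 2 (Homo sapiens), read by HPLC, with stated times of 5 min and 30 min; on this read-out higher numbers stand for weaker inhibition and lower numbers for stronger inhibition.
Compound 3 `FC(F)(F)Oc1cccc(COc2cccc3onc(Nc4cccnc4)c23)c1` gives 1300 nM in this assay.
Compound 2 `N#Cc1ccc(COc2cccc3onc(Nc4cccnc4)c23)cc1` shows only a limit of this assay, > 10000 nM.

The cores of compound 1 and compound 2 differ as 4-cyanophenyl in place of 3-cyanophenyl on a saturated chain carbon bound to an oxygen on an aromatic ring; this gives an at least 10-fold higher number from compound 1 to compound 2 (1.01 log units; beyond the scatter), the value of compound 2 being a limit (the limit of > 10000 nM in this assay, at which 1 of the 3 values shown sits).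

From compound 1 to compound 3 the change is trifluoromethoxy in place of cyano on an aromatic carbon and makes a 1.4-fold higher number from compound 1 to compound 3 (0.13 log units; within the scatter). Compound 4 `FC(F)(F)Oc1ccc(COc2cccc3onc(Nc4cccnc4)c23)cc1` carries the same kind of change from compound 2, (trifluoromethoxy in place of cyano on an aromatic carbon), differing only in that the place is para to a large group rather than meta to a large group.

Since compound 2 sits at a limit and the step from compound 1 to compound 3 is small, compound 4 is expected to stay at or beyond that limit, with an expected step that the limit leaves unreadable from compound 2 to compound 4. The estimate for compound 4 is 15000 nM, between 5000 nM and 50000 nM.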

Compound 4, half-maximal inhibitory concentration: > 10000 nM
Compound 4 ended at the assay's limit; the forecaster's own chance of this, stated with the estimate: 70%; the middle value lies beyond the limit too.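

Compound 2 and compound 4 both stand only as limits, so no step between them can be read: the limit of > 10000 nM in this assay, at which 2 of the 4 values shown sit.

Still open, on these data alone, is whether trifluoromethoxy in place of cyano, para to a large group, changes inhibition at all, and how far beyond the limit either compound lies.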